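Swapping the aryl amide for a tetrahydropyranyl acetamide

The source may hold more compounds than are shown below. What is called first, only, known or untested is meant among the compounds shown, and "the series" means these compounds.

Measured in an ADME assay (liver) for metabolic stability, with Liver microsome (Homo sapiens) as the target, read by LC-MS, using microsomes and NADPH, tested at 1 uM; a higher number here means that the compound lasts longer, a lower number that the compound disappears faster:
- compound 1 `CC(C)(C)c1cc(NC(=O)[C@@H]2CCCCN2CC2CCOCC2)no1`: 0.183 h
- compound 2 `CC(C)(C)c1cc(NC(=O)[C@@H]2CCCCN2C(=O)c2ccccc2)no1`: 0.683 h
- compound 3 `CC(C)(C)c1cc(NC(=O)[C@@H]2CCCCN2C(=O)c2ccc(Cl)cc2)no1`: 1.25 h

Compound 3 has the highest number of the three, but its gap to compound 2 is within the scatter, so the two cannot be ordered; only compound 1 sits clearly lower. The unmeasured compound 4 `CC(C)(C)c1cc(NC(=O)[C@@H]2CCCCN2C(=O)CC2CCOCC2)no1` keeps the amide of compound 3 and changes one group: (oxan-4-yl)methyl in place of 4-chlorophenyl on a carbonyl carbon. For the measured compounds named here, two measured steps bear on this. Replacing (oxan-4-yl)methyl on the ring nitrogen by an aroyl group gave a 3.7-fold higher number from compound 1 to compound 2 (0.57 log units; beyond the scatter) and a 6.8-fold higher number from compound 1 to compound 3 (0.83 log units; beyond the scatter), while the chloro addition gave only a 1.8-fold higher number from compound 2 to compound 3 (0.26 log units; within the scatter). Going by the values given here, compound 4 brings the (oxan-4-yl)methyl group back, now on the carbonyl carbon rather than directly on the nitrogen, so it is neither compound 1 nor an aroyl amide; no measured pair shows this exact exchange. Weighing the loss of the aromatic ring against retention of the amide, a drop in this assay is expected for compound 4, of roughly a 2.5-fold lower number from compound 3 to compound 4 (0.40 log units; beyond the scatter). Compound 4 is therefore estimated at 0.5 h, with a likely range from 0.2 h to 1.3 h.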

Compound 4, half-life: 1.83 h
Beside the measured number, compound 4's estimate is 3.7-fold (0.56 log units) below it; the measured number lies above the stated range.
By their numbers in this assay, from the lowest: compound 1; then compounds 2, 3 and 4 (each within the scatter of the next, the first and the last beyond it).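

Measured in this assay, the group on this carbonyl carbon need not be aromatic. Replacing 4-chlorophenyl with (oxan-4-yl)methyl gives a 1.5-fold higher number from compound 3 to compound 4 (0.17 log units; within the scatter), so these two compounds cannot be ordered, while replacing phenyl with the same group gives a 2.7-fold higher number from compound 2 to compound 4 (0.43 log units; beyond the scatter). The (oxan-4-yl)methyl group also gives a very different result when a carbonyl links it to the ring nitrogen, with a 10-fold higher number from compound 1 to compound 4 (1.00 log units; beyond the scatter), so among these compounds the low number of compound 1 goes with having no carbonyl on that nitrogen, not with having no aromatic ring. Nothing available here accounts for either result.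

The compounds shown leave open how much of the (oxan-4-yl)methyl group matters, since a cyclohexylmethyl group, which has carbon in place of the ring oxygen, or a plain methyl group on the same carbonyl carbon would separate the contribution of the ring oxygen from that of the ring itself. As far as these compounds go, it also remains open whether an amine or a carboxylic acid at the end of a longer chain at this place would keep the number as high as in compound 4.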